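Trimming the Ester Tail of Compound 1: An Expectation

The compounds below may be only part of what the source reports. "The series", "measured", "known", "first", "only" and "open" are said of these compounds alone.

Compound 1 `C/C=C1/[C@H](O[C@@H]2O[C@H](CO)[C@@H](O)[C@H](O)[C@H]2O)OC=C(C(=O)OC)[C@H]1CC(=O)OCCc1ccc(OC)c(OC)c1` was tested in a functional assay on SK-BR-3 cells (Homo sapiens) for antiproliferative activity, read by MTT assay, with a stated time of 72 h (a lower number here means a stronger inhibitor, a higher number a weaker inhibitor), and gave only a limit of the assay, > 15000 nM. Compound 2 `C/C=C1/[C@H](O[C@@H]2O[C@H](COC(C)=O)[C@@H](OC(C)=O)[C@H](OC(C)=O)[C@H]2OC(C)=O)OC=C(C(=O)OC)[C@H]1CC(=O)SCCC` likewise gave a limit in this assay, > 15000 nM. Compound 3 `C/C=C1/[C@H](O[C@@H]2O[C@H](COC(C)=O)[C@@H](OC(C)=O)[C@H](OC(C)=O)[C@H]2OC(C)=O)OC=C(C(=O)O)[C@H]1CC(=O)O` also gave a limit in this assay, > 20000 nM. Compound 1 therefore stands at the limit of > 15000 nM in this assay, at which 2 of the 3 values shown sit, and compound 3 sits at the limit of > 20000 nM in this assay, at which 1 of the 3 values shown sits. Since every value shown is a limit, no measured step between any two of these compounds can be read, and nothing separates compound 1 from the others beyond the scatter.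

Compound 4 `C/C=C1/[C@H](O[C@@H]2O[C@H](CO)[C@@H](O)[C@H](O)[C@H]2O)OC=C(C(=O)OC)[C@H]1CC(=O)OCCCC` differs from compound 1 by ethyl in place of 3,4-dimethoxyphenyl on a saturated chain carbon, two bonds along the chain from an oxygen next to a carbonyl group. Among the compounds with values here, with no resolved step among the measured compounds and compound 1 itself at a limit, the change from compound 1 to compound 4 is expected to amount to none beyond the scatter, as expressed by a step that the limit leaves unreadable from compound 1 to compound 4. Compound 4 is expected to give about 20000 nM in this assay, within a range of 8000 nM to 60000 nM, and it is likely to be reported again only as a limit.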

Compound 4, half-maximal inhibitory concentration: > 15000 nM
Compound 4 gave a limit, no number (the forecaster's own chance of this, stated with the estimate: 85%); the middle value does not contradict the limit.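

In this assay compound 4 gave > 15000 nM, a limit and not a number. Within the data shown here, compound 1 also stands at a limit, so no step between compound 1 and compound 4 can be read. The compounds shown leave open whether any change to the ester tail gives a measurable value in this assay.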